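Replacing a Bromoalkyl Tail with an Isopropylamine

A few compounds are considered here, and "the series" means these few. Any claim that something is new, unique, unknown or untested is made for them only; others in the source may bear on it.

Three measured compounds share one core and differ only in a side chain attached through an oxygen on an aromatic ring. Compound 1 `COc1cc2ccc(=O)oc2cc1OCCCCBr` carries a bromoalkyl chain; in a functional assay on HUVEC cells (Homo sapiens) for inhibition, read by MTT assay, with a stated time of 24 h, tested at 100 uM (a higher number here means more inhibition of growth at the concentration tested, a lower number less inhibition of growth), compound 1 gives 16.9%, the lowest of the three numbers. Going by the values given here, compound 2 `COc1cc2ccc(=O)oc2cc1OCC(=O)c1ccccc1` gives 83.6% and compound 3 `COc1cc2ccc(=O)oc2cc1OCC(=O)c1ccc(Cl)cc1` gives 83.8%; the only measured single change, a number 0.2 percentage points higher from compound 2 to compound 3 (within the scatter), touches a different part of the chain. The unmeasured compound 4 `COc1cc2ccc(=O)oc2cc1OCCNC(C)C` differs from compound 1 by isopropylamino in place of 2-bromoethyl on a saturated chain carbon, two bonds along the chain from an oxygen on an aromatic ring. Among the compounds with values here, no measured step covers this kind of change, so the expectation rests only on compound 1, whose value of 16.9% is the lowest of the three, the other two standing far higher. Compound 4 is therefore expected near 35%, within a range from 10% to 65%, an estimated step of a number 18.1 percentage points higher from compound 1 to compound 4 (beyond the scatter).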

Compound 4, percent growth inhibition at one concentration: 0.1%
Estimate against measurement, compound 4: 34.9 percentage points above, outside the stated range (below it).
By their numbers in this assay, from the lowest: compound 4; then compound 1; then compounds 2 and 3 (each within the scatter of the next).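

Putting isopropylamino in place of 2-bromoethyl, on a saturated chain carbon, two bonds along the chain from an oxygen on an aromatic ring, gives a modest fall in this assay: a number 16.8 percentage points lower from compound 1 to compound 4 (beyond the scatter). Compound 4 gives 0.1%, almost no inhibition at the concentration tested, so this amine chain adds nothing over the bromoalkyl tail. Nothing measured here explains the fall. Still open, as far as these compounds go, is whether a piperidine, a carboxylic acid, or a longer chain carrying the same isopropylamino would behave in the same way.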